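This account rests on a few compounds, and the source may have more. Where it says the series, first, only, none or still open, it means among the compounds named here.

Working notes on an ADME assay on the whole organism (Rattus norvegicus) for pharmacokinetics, at a dose of 1 mg/kg by the oral route; a higher number here means more compound in the circulation at the dose given, a lower number less compound in the circulation. Compound 1 `COc1ccc(F)cc1-c1ccnc2[nH]c(C3=CCN([C@H]4CC[C@H](C(=O)O)CC4)CC3)cc12` gives 400 ng.h/mL, and compound 3 `COc1ccc(F)cc1-c1c(F)cnc2[nH]c(C3=CCN([C@H]4CC[C@H](C(=O)O)CC4)CC3)cc12`, with fluoro in place of hydrogen on an aromatic carbon, gives 450 ng.h/mL. That step is a 1.1-fold higher number from compound 1 to compound 3 (0.05 log units; within the scatter). Compound 2 `COc1ccc(F)cc1-c1ccnc2[nH]c(C3=CCN([C@H]4CC[C@@H](C(=O)O)CC4)CC3)cc12` gives 160 ng.h/mL, and the step to it is a 2.5-fold lower number from compound 1 to compound 2 (0.40 log units; beyond the scatter). The only thing that separates this pair is the fact that compounds 1 and 2 differ only in the configuration as drawn. Compound 3 therefore sits with compound 1 as the upper pair of the three numbers, while compound 2 lies beyond the scatter of both.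

Compound 4 `COc1ccc(F)cc1-c1c(F)cnc2[nH]c(C3=CCN([C@H]4CC[C@@H](C(=O)O)CC4)CC3)cc12` is related to compound 3 by one change: the two compounds have the same atoms and bonds and differ only in configuration as drawn: 2 of 2 stereo elements differ (all stereocentres are inverted: mirror images); a stereocentre at a saturated ring carbon is drawn r in compound 3 and s in compound 4; a stereocentre at a saturated ring carbon is drawn r in compound 3 and s in compound 4. No atoms leave or enter. Among the compounds with values here, the only measured step of this same kind is a 2.5-fold lower number from compound 1 to compound 2 (0.40 log units; beyond the scatter), so it sets the expected size and direction. The fluoro step, a 1.1-fold higher number from compound 1 to compound 3 (0.05 log units; within the scatter), gives no sign that the added fluoro shifts this assay on its own, so the earlier inversion step is expected to carry over, though this rests on a single pair. A modest fall beyond the scatter is expected, and the estimated step is a 2.5-fold lower number from compound 3 to compound 4 (0.40 log units; beyond the scatter). For compound 4 the estimated value is 180 ng.h/mL, with an expected range of 95 ng.h/mL to 340 ng.h/mL.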

Compound 4, area under the concentration-time curve: 140 ng.h/mL
Compound 4: middle estimate off by 1.3-fold (0.11 log units), on the high side; the range from low to high includes it.
By their numbers in this assay, from the lowest: compounds 4 and 2 (each within the scatter of the next); then compounds 1 and 3 (each within the scatter of the next).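

In this assay, inverting both stereocentres at the saturated ring carbons now lowers the number on a second core (a 3.2-fold lower number from compound 3 to compound 4 (0.51 log units; beyond the scatter)), in the same direction as the earlier step (a 2.5-fold lower number from compound 1 to compound 2 (0.40 log units; beyond the scatter)), so this change no longer rests on a single pair: the fact that compounds 3 and 4 differ only in the configuration as drawn. Fluoro in place of hydrogen on an aromatic carbon can now also be read in both configurations, and the new step (a 1.1-fold lower number from compound 2 to compound 4 (0.06 log units; within the scatter)) stays within the scatter, as the earlier one did (a 1.1-fold higher number from compound 1 to compound 3 (0.05 log units; within the scatter)): the same change on two cores in this assay, a 1.1-fold higher number (0.05 log units; within the scatter) from compound 1 to compound 3 and a 1.1-fold lower number (0.06 log units; within the scatter) from compound 2 to compound 4, 1.3-fold (0.11 log units) apart, within the scatter of two such steps. Across these four compounds, configuration as drawn separates compounds 1 and 3 from compounds 2 and 4, while the fluoro change does not, and no compound shown goes against this.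

The area under the curve after an oral dose gives one number for each compound. It does not show which process in the animal sets the lower numbers. Also open, on these data alone, is whether the configuration step holds with an amide or a tetrazole in place of the carboxylic acid, and whether chloro or methyl on that aromatic carbon would stay as silent as fluoro.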